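Replacing one group of compound 3 with (pyrrolidin-1-yl)carbonyl

The source may hold more compounds than are shown below. What is called first, only, known or untested is meant among the compounds shown, and "the series" means these compounds.

Compound 1 `CC(C)=CCC[C@]1(C)/C=C/[C@@H](OC(=O)C=C(C)C)[C@](C)(O)/C=C/C(=O)/C(C(=O)O)=C\C1`: > 10000 nM
Compound 2 `CCN(CC)C/C1=C/C[C@](C)(CCC=C(C)C)/C=C/[C@@H](OC(=O)C=C(C)C)[C@](C)(O)/C=C/C1=O`: 570 nM
Compound 3 `CO/N=C/C1=C/C[C@](C)(CCC=C(C)C)/C=C/[C@@H](OC(=O)C=C(C)C)[C@](C)(O)/C=C/C1=O`: 3470 nM

In a functional assay on SMMC-7721 cells (Homo sapiens) for antiproliferative activity, read by MTT assay, with a stated time of 48 h (a lower number here means a stronger inhibitor, a higher number a weaker inhibitor), compound 3 gives 3470 nM, the higher of the two values that are true numbers. Its nearest neighbour is compound 2 at 570 nM. For compound 1 the reading > 10000 nM is a limit of the assay, not a number.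

Compound 4 `CC(C)=CCC[C@]1(C)/C=C/[C@@H](OC(=O)C=C(C)C)[C@](C)(O)/C=C/C(=O)/C(C(=O)N2CCCC2)=C\C1` differs from compound 3 in one group: a group of 7 heavy atoms (5 carbon, 1 nitrogen, 1 oxygen; one five-membered non-aromatic ring with 1 hetero atom) in place of a group of 4 heavy atoms (2 carbon, 1 nitrogen, 1 oxygen; no ring), on a double-bonded ring carbon. The exchange falls on a double-bonded ring carbon of the shared core.

Within the data shown here, three measured steps concern this same carbon: an at least 17-fold lower number from compound 1 to compound 2 (1.24 log units; beyond the scatter), an at least 2.8-fold lower number from compound 1 to compound 3 (0.45 log units; beyond the scatter) and a 6.1-fold higher number from compound 2 to compound 3 (0.78 log units; beyond the scatter). All three lie beyond the scatter, so a real shift at this carbon is possible, but none of them tests a (pyrrolidin-1-yl)carbonyl group. Compound 4 keeps a carbonyl on this carbon, as compound 1 does, and an at least 2.8-fold lower number from compound 1 to compound 3 (0.45 log units; beyond the scatter) therefore tilts the expectation slightly toward a higher number.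

The expected change is small: a 1.4-fold higher number from compound 3 to compound 4 (0.16 log units; within the scatter). For compound 4 the estimated value in this assay is 5000 nM, with an expected range of 1500 nM to 15000 nM.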

Compound 4, half-maximal inhibitory concentration: 14900 nM
Compound 4: the middle estimate sits 3.0-fold (0.47 log units) below what was measured, and the stated range covers the measured number.
By their numbers in this assay, from the lowest: compound 2; then compound 3; then compound 4.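

Among these compounds, the result gives the first true number in this assay for a carbonyl-bearing group on this double-bonded ring carbon, and that number lies on the weak side of the series: a 4.3-fold higher number from compound 3 to compound 4 (0.63 log units; beyond the scatter), and a 26-fold higher number from compound 2 to compound 4 (1.42 log units; beyond the scatter). Both steps lie beyond the scatter, so among the three groups with true numbers, the order at this carbon runs from (diethylamino)methyl through the group of compound 3 to (pyrrolidin-1-yl)carbonyl, and adding a ring and more heavy atoms here does not by itself lower the number. The step between compound 1 and compound 4 cannot be read, because compound 1 carries only a limit of the assay: the limit of > 10000 nM in this assay, at which 1 of the 4 values shown sits.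

The compounds shown do not separate the carbonyl from the pyrrolidine ring, and a pyrrolidin-1-ylmethyl group or a diethylamide on this carbon would tell the two apart. Going by these compounds, all four compounds also carry the same ((2-methylprop-1-en-1-yl)carbonyl)oxy group, so it remains open whether the order at this carbon would hold with a different ester or a free hydroxy group there.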